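Shrinking the ring on the indole nitrogen

The source may report more compounds than this note shows. Statements on the series, on what has been measured and on what is new or still open speak of the compounds shown alone.

Compound 2 `O=S(=O)(c1ccccc1)c1cn(C2CCNCC2)c2ccccc12` gives 91 nM in an assay on HeLa cells for displacement of a labelled ligand from 5-hydroxytryptamine receptor 6 (Homo sapiens), with a stated time of 2 h (on this read-out lower numbers stand for stronger inhibition and higher numbers for weaker inhibition), the highest number among the three measured compounds. Compound 1 `O=S(=O)(c1ccccc1)c1cn(C2CCN(Cc3ccccc3)CC2)c2ccccc12`, which carries a benzyl on the ring amine, gives 49 nM, and the step of a 1.9-fold higher number from compound 1 to compound 2 (0.27 log units; within the scatter) stays within the scatter. Within the data shown here, compound 3 `CN1CCC(n2cc(S(=O)(=O)c3cccc4ccccc34)c3ccccc32)C1` gives 6 nM, but it differs from compound 2 in more than one place, so no single step links the two.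

Compound 4 `O=S(=O)(c1ccccc1)c1cn(C2CCNC2)c2ccccc12` is compound 2 with pyrrolidin-3-yl in place of piperidin-4-yl on an aromatic nitrogen. Among the measured compounds shown here, no measured step changes this ring, so nothing directly bears on the change; the only measured step, from compound 1 to compound 2, touches a different position and is small. Compound 3 carries a pyrrolidin-3-yl on the aromatic nitrogen and gives a lower number, which hints that this ring is tolerated. Compound 3 also differs from compound 2 in other places, so its number alone does not settle the change. The step of a 1.5-fold lower number from compound 2 to compound 4 (0.18 log units; within the scatter) is therefore expected to stay within the scatter. Compound 4 is estimated at 60 nM, with a range from 20 nM to 180 nM.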

Compound 4, inhibition constant: 5 nM
Compound 4: middle estimate off by 12-fold (1.08 log units), on the high side; the whole stated range lies above it.
By their numbers in this assay, from the lowest: compounds 4 and 3 (each within the scatter of the next); then compounds 1 and 2 (each within the scatter of the next).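

Replacing piperidin-4-yl with pyrrolidin-3-yl on the aromatic nitrogen gives an 18-fold lower number from compound 2 to compound 4 (1.26 log units; beyond the scatter) in this assay. This position therefore responds strongly to a change from a six-membered to a five-membered ring, something the earlier step at the ring amine, a 1.9-fold higher number from compound 1 to compound 2 (0.27 log units; within the scatter), could not show. Nothing measured here explains why the five-membered ring gives the lower number.

From the compounds shown here alone, it remains open how the read-out would respond to a smaller azetidin-3-yl ring or a larger azepan-4-yl ring on the same nitrogen, which would show whether the five-membered ring is a sharp optimum or part of a wider trend. Among these compounds, also unresolved is how much each of the other structural differences in compound 3 contributes when pyrrolidin-3-yl is present, since no single step links compound 3 to compound 4.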